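Thiophen-2-yl in place of 4-fluorophenyl on the shared core

The compounds below may be only part of what the source reports. "The series", "measured", "known", "first", "only" and "open" are said of these compounds alone.

In a functional assay on MOLT-4 cells (Homo sapiens) for antiproliferative activity (on this read-out lower numbers stand for stronger inhibition and higher numbers for weaker inhibition), compound 1 `COc1ccc(-c2cc(N)c(C(=O)c3cc(OC)c(OC)c(OC)c3)s2)cc1OC` gives 20 nM and compound 2 `COc1cc(C(=O)c2sc(-c3ccc(F)cc3)cc2N)cc(OC)c1OC` gives 12 nM, two numbers that lie within the usual scatter of each other. Compound 3 `COc1cc(C(=O)c2sc(-c3cccs3)cc2N)cc(OC)c1OC` carries thiophen-2-yl in place of 4-fluorophenyl on an aromatic carbon. Within the data shown here, the one measured step at this place, a 1.7-fold lower number from compound 1 to compound 2 (0.22 log units; within the scatter), stayed within the scatter, so no change beyond the scatter is expected in this assay. The expected step is a 1.3-fold higher number from compound 2 to compound 3 (0.10 log units; within the scatter). For compound 3 the estimate is 15 nM, with an expected range of 5 nM to 45 nM.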

Compound 3, half-maximal inhibitory concentration: 8.9 nM
Estimate against measurement, compound 3: 1.7-fold (0.23 log units) above, within the range that was stated.
By their numbers in this assay, from the lowest: compounds 3, 2 and 1 (each within the scatter of the next, the first and the last beyond it).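

At this place on the shared core, a six-membered aromatic ring can give way to a five-membered one with little change: in this assay, thiophen-2-yl in place of 4-fluorophenyl gives a step within the scatter (a 1.3-fold lower number from compound 2 to compound 3 (0.13 log units; within the scatter)). Thiophen-2-yl in place of 3,4-dimethoxyphenyl gives the first step at this place beyond the scatter, though a modest one (a 2.2-fold lower number from compound 1 to compound 3 (0.35 log units; beyond the scatter)). No measurement at hand accounts for these numbers. Still open, as far as these compounds go, is whether this place needs an aromatic ring at all, which a morpholine or an ethyl group could test.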